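A few compounds are considered here, and "the series" means these few. Any claim that something is new, unique, unknown or untested is made for them only; others in the source may bear on it.

compound 1 `O=C(CCC1CCCC1)N1CCCN(C(=O)Nc2ccccc2)CC1` — 0.05 h
compound 2 `CC(C)c1ccc(NC(=O)N2CCCN(C(=O)CCC3CCCC3)CC2)cc1` — 0.117 h
compound 3 `CC(C)(C)c1ccc(NC(=O)N2CCCN(C(=O)CCC3CCCC3)CC2)cc1` — 0.05 h

These three share one core and differ only in the group on an aromatic carbon at the urea end; all were run in an in vitro ADME assay on microsomes from liver (Homo sapiens) for metabolic stability, read by LC-MS; on this read-out lower numbers stand for a shorter-lived compound and higher numbers for a longer-lived compound. Compound 3 stands at the bottom of this small set, level with compound 1: no change at the digits printed from compound 1 to compound 3 (within the scatter). Compound 2 sits higher, as a 2.3-fold higher number from compound 1 to compound 2 (0.37 log units; beyond the scatter) and a 2.3-fold lower number from compound 2 to compound 3 (0.37 log units; beyond the scatter) show. Compound 4 `CC(C)(C)c1ccc(NC(=O)N2CCCN(C(=O)c3ccc(C(F)(F)F)cc3)CC2)cc1` keeps the tert-butyl of compound 3 and changes the other end: 4-(trifluoromethyl)phenyl in place of 2-cyclopentylethyl on a carbonyl carbon. Going by the values given here, none of the measured steps touches that end, so they give no guide to the direction of this change; all that is known is that every number so far is low. Compound 4 is therefore estimated at 0.08 h, within a range from 0.03 h to 0.25 h. The expected step of a 1.6-fold higher number from compound 3 to compound 4 (0.20 log units; within the scatter) stays within the scatter.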

Compound 4, half-life: 0.0667 h
Beside the measured number, compound 4's estimate is 1.2-fold (0.08 log units) above it; the measured number falls inside the stated range.
By their numbers in this assay, from the lowest: compounds 1, 3, 4 and 2 (each within the scatter of the next, the first and the last beyond it).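

In this assay, 4-(trifluoromethyl)phenyl in place of 2-cyclopentylethyl on the carbonyl carbon gives a 1.3-fold higher number from compound 3 to compound 4 (0.13 log units; within the scatter) and so no change that can be told from scatter. Going by these compounds alone, this end of the molecule, which no earlier step touched, can thus carry an aromatic ring instead of a saturated one while the half-life stays short. No measurement on hand explains why this exchange leaves the number where it is.

Going by these compounds, whether an amine or a carboxylic acid on this carbonyl carbon would lengthen the half-life stays open. So does whether 4-(trifluoromethyl)phenyl would behave the same alongside the isopropyl of compound 2.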